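This account rests on a few compounds, and the source may have more. Where it says the series, first, only, none or still open, it means among the compounds named here.

The series shares one core, seen in compound 1 `O=C(CSc1nc(Nc2ccccc2)c2ccccc2n1)Nc1ccccc1F`. In a functional assay on MDA-MB-231 cells (Homo sapiens) for inhibition, read by MTT assay, with a stated time of 72 h (on this read-out higher numbers stand for weaker inhibition and lower numbers for stronger inhibition), compound 1 gives only a limit of the assay, > 50000 nM (the limit of > 50000 nM in this assay, at which 1 of the 3 values shown sits). Compound 2 `O=C(CSc1nc(Nc2ccccc2)c2ccccc2n1)Nc1cccc(Cl)c1` in this assay gives 16500 nM, a step of an at least 3.0-fold lower number from compound 1 to compound 2 (0.48 log units; beyond the scatter). Compound 3 `C=CC(=O)Nc1cccc(NC(=O)CSc2nc(Nc3cccc(C)c3)c3ccccc3n2)c1` in this assay gives 16800 nM, the highest of the two numbers, though its gap to compound 2 lies within the scatter. Compound 4 `C=CC(=O)Nc1cccc(NC(=O)CSc2nc(Nc3ccc(F)c(Cl)c3)c3ccccc3n2)c1` has not yet been measured. It differs from compound 3 in 3-chloro-4-fluorophenyl in place of 3-methylphenyl on a nitrogen on an aromatic ring. Going by the values given here, the single measured step, from compound 1 to compound 2, puts 3-chlorophenyl in place of 2-fluorophenyl on an amide-type nitrogen, which is a different place from the nitrogen on the aromatic ring changed here, so it bears only loosely on the present change; compounds 2 and 3 differ at both places, and their values sit within the scatter of each other. Nothing measured speaks for a move in either direction, so compound 4 is expected to show a 1.1-fold lower number from compound 3 to compound 4 (0.05 log units; within the scatter), a step not beyond the scatter. Compound 4 is therefore estimated at 15000 nM, with a range from 6000 nM to 40000 nM.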

Compound 4, half-maximal inhibitory concentration: 10600 nM
For compound 4 the middle estimate is 1.4-fold (0.15 log units) above the measured one, and the stated range covers the measured number.
By their numbers in this assay, from the lowest: compounds 4, 2 and 3 (each within the scatter of the next). At a limit, above all of these: compound 1.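

On the nitrogen on an aromatic ring, 3-chloro-4-fluorophenyl in place of 3-methylphenyl gives, in this assay, a 1.6-fold lower number from compound 3 to compound 4 (0.20 log units; within the scatter). Going by these compounds alone, the earlier compounds offered no step at this place alone, since compounds 2 and 3 differ at two places at once, so this is the first direct reading of the position, and it shows that this exchange of one substituted phenyl for another leaves the number unresolved from that of compound 3. Nothing measured here gives a reason for the size of this step.

From the compounds shown here alone, it remains open whether a group of a different kind on that nitrogen, such as a phenyl carrying an amine or a carboxylic acid, or a longer chain in place of the phenyl, would produce a step beyond the scatter. Within the data shown here, also open is how much the group on the amide-type nitrogen contributes with the aminophenyl part held fixed, as its only single-place step, the change from compound 1 to compound 2, starts from a limit and involves neither compound 3 nor compound 4.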